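Propyl in Place of Hydrogen on the Ring Amine

The source may report more compounds than this note shows. Statements on the series, on what has been measured and on what is new or still open speak of the compounds shown alone.

Three diaryl ether ureas were tested in an assay on isolated protein for inhibition of serine/threonine-protein kinase TNNI3K (Homo sapiens); a higher number here means a weaker inhibitor, a lower number a stronger inhibitor. Compound 1 `CNc1cc(Oc2c(F)cc(NC(=O)Nc3cccc(C(F)(F)F)c3)cc2F)ncn1` gives 20 nM. Compound 2 `Nc1cc(Oc2ccc(NC(=O)Nc3cccc(C(F)(F)F)c3)cc2)ncn1` gives 25 nM, the higher of the two numbers shown, though it lies within the usual scatter of compound 1. For compound 3 `CCc1cc(NC(=O)Nc2cccc(C(F)(F)F)c2)cc(Cl)c1Oc1cc(NC)ncn1` the assay reports only a limit, <= 10 nM. Compound 4 `CCCNc1cc(Oc2ccc(NC(=O)Nc3cccc(C(F)(F)F)c3)cc2)ncn1` differs from compound 2 in one place: propyl in place of hydrogen on a nitrogen on an aromatic ring. For the measured compounds named here, no measured pair isolates this change, so its size cannot be read from the data. Since compound 1 carries a methylamino at that spot and its number sits within the scatter of compound 2, the step from compound 2 to compound 4 is expected to be small or none beyond the scatter, a 1.6-fold lower number from compound 2 to compound 4 (0.19 log units; within the scatter). Compound 4 is therefore estimated at 16 nM, with a range from 5 nM to 45 nM.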

Compound 4, half-maximal inhibitory concentration: 32 nM
Compound 4: the middle estimate sits 2.0-fold (0.30 log units) below what was measured; low and high end bracket the measured number.
By their numbers in this assay, from the lowest: compounds 1, 2 and 4 (each within the scatter of the next). At a limit, below all of these: compound 3.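

For the compounds shown here, this is the first pair that isolates propyl in place of hydrogen on a nitrogen on an aromatic ring. In this assay the change gives a 1.3-fold higher number from compound 2 to compound 4 (0.11 log units; within the scatter) and so leaves the number indistinguishable from that of the unsubstituted amino group: this nitrogen tolerates a propyl chain. No measurement shown bears on why the step stays this small.

From the compounds shown here alone, whether a longer chain such as hexyl, a branched group such as isopropyl, or a chain ending in a hydroxyl or an amine would also leave the number unchanged remains open.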